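This account rests on a few compounds, and the source may have more. Where it says the series, first, only, none or still open, it means among the compounds named here.

Measured so far in a functional assay on CHO-K1 cells for antagonist activity at melanin-concentrating hormone receptor 1 (Homo sapiens), read by inositol phosphate accumulation; on this read-out higher numbers stand for weaker inhibition and lower numbers for stronger inhibition:
compound 1 `Cc1nc(N2CCC(C)(O)CC2)nc2ccc(NC(=O)COc3ccc(Cl)cc3)cc12` gives 827 nM
compound 2 `CCN1CCN(c2nc(C)c3cc(NC(=O)COc4ccc(Cl)cc4)ccc3n2)CC1` gives "not determined" (no result reported)
compound 3 `Cc1nc(N2CCN(CC(C)(C)C)CC2)nc2ccc(NC(=O)COc3ccc(Cl)cc3)cc12` gives 246 nM

Among the measured compounds shown here, compound 3 holds the lowest number of the two that were measured; its nearest neighbour is compound 1, and the single step on record, a 3.4-fold lower number from compound 1 to compound 3 (0.53 log units; beyond the scatter), places 4-neopentylpiperazin-1-yl in place of 4-hydroxy-4-methylpiperidin-1-yl on an aromatic carbon of the shared core. Compound 2 gives no number to compare.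

Compound 4 `Cc1nc(N2CCN(C3CCCC3)CC2)nc2ccc(NC(=O)COc3ccc(Cl)cc3)cc12` differs from compound 3 by cyclopentyl in place of neopentyl on an amine nitrogen in a ring. For the measured compounds named here, no measured pair addresses this kind of exchange: the one step known, from compound 1 to compound 3, replaces the entire ring system at that position and brings in a heavy-atom count and ring change that the present swap does not repeat, the group leaving and the group entering being matched in what is counted. It therefore offers no direct guide to the direction or size of the step into compound 4. Without a bearing step, the working expectation is that the number for compound 4 stays close to that of compound 3, with a 1.0-fold higher number from compound 3 to compound 4 (0.01 log units; within the scatter) expected to lie within the scatter in either direction. Compound 4 is accordingly estimated at 250 nM, within a range of 100 nM to 650 nM.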

Compound 4, half-maximal inhibitory concentration: 150 nM
Compound 4: the middle estimate sits 1.7-fold (0.22 log units) above what was measured; low and high end bracket the measured number.
By their numbers in this assay, from the lowest: compounds 4 and 3 (each within the scatter of the next); then compound 1.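

In this assay, the step from an open chain to a ring on the amine nitrogen, a 1.6-fold lower number from compound 3 to compound 4 (0.21 log units; within the scatter), leaves the two compounds level, so at this position cyclopentyl serves as well as neopentyl, with the count of heavy atoms unchanged. The other new step, a 5.5-fold lower number from compound 1 to compound 4 (0.74 log units; beyond the scatter), lies beyond the scatter and, like a 3.4-fold lower number from compound 1 to compound 3 (0.53 log units; beyond the scatter), favours a substituted piperazine over the 4-hydroxy-4-methylpiperidin-1-yl group, now with two different groups on that nitrogen. Nothing on hand explains either step.

Still open, going by these compounds, is whether a cyclohexyl or benzyl group, or a ring carrying an oxygen atom such as tetrahydropyranyl, would hold the number at this nitrogen. Also open, on these data alone, is how far these readings carry over to a shared core with a group other than the chlorine on its phenoxy ring.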